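From 4-fluoro-3-nitrophenyl to 4-bromo-3-nitrophenyl

The compounds below may be only part of what the source reports. "The series", "measured", "known", "first", "only" and "open" are said of these compounds alone.

In a functional assay on DU-145 cells (Homo sapiens) for inhibition, read by trypan blue exclusion, with a stated time of 96 h (on this read-out lower numbers stand for stronger inhibition of growth and higher numbers for weaker inhibition of growth), compound 1 (`O=C(O)c1ccc(C(=O)/C(=C\c2ccc(Br)c([N+](=O)[O-])c2)SCc2ccccc2Cl)cc1`) gives 1000 nM and compound 2 (`O=C(O)c1ccc(C(=O)/C(=C\c2ccc(F)c([N+](=O)[O-])c2)SCc2ccc(F)cc2)cc1`) gives 1000 nM so the two stand level within the scatter. Compound 3 (`O=C(O)c1ccc(C(=O)/C(=C\c2ccc(Br)c([N+](=O)[O-])c2)SCc2ccc(F)cc2)cc1`) has not yet been measured. It carries bromo in place of fluoro on an aromatic carbon, ortho to a nitro group and para to a large group (bromo in place of fluoro on an aromatic carbon). Among the compounds with values here, no measured step isolates this change, so no shift beyond the scatter is expected in this assay and no direction is favoured. The expected step is no change at the digits printed from compound 2 to compound 3 (within the scatter) and it is estimated to lie within the scatter. For compound 3 the estimated value is 1000 nM (expected range 500 nM to 2000 nM).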

Compound 3, concentration for 50% growth inhibition: 1000 nM
Beside the measured number, compound 3's estimate shows no gap at the digits printed; measured number inside the range.
By their numbers in this assay, from the lowest: compounds 1, 2 and 3 (each within the scatter of the next).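

In this assay, within the data shown here, bromo in place of fluoro on the aromatic carbon ortho to the nitro group gives no change at the digits printed from compound 2 to compound 3 (within the scatter), the first reading that isolates this position. 4-fluorophenyl in place of 2-chlorophenyl on the saturated chain carbon bound to a sulfur gives no change at the digits printed from compound 1 to compound 3 (within the scatter), so neither single change separates these compounds in this assay. Nothing available explains why these pairs read alike.

Going by these compounds, whether an amine or a methoxy group on that aromatic carbon would read differently stays open. So does whether the bromo-to-fluoro step would also read level with the 2-chlorophenyl group on the chain.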